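Swapping a Fluorine Position on the Pyrazolone-Bound Phenyl Ring

The source may report more compounds than this note shows. Statements on the series, on what has been measured and on what is new or still open speak of the compounds shown alone.

Of the compounds shown here, two have been measured in a functional assay on HepG2 cells (Homo sapiens) for cytotoxicity, read by MTT assay, with a stated time of 72 h; a lower number here means a stronger inhibitor, a higher number a weaker inhibitor. Compound 1 `Cc1cc(=O)n(-c2ccc(F)cc2)nc1C(=O)Nc1ccc(Oc2ncnc3ccsc23)c(F)c1` gives 470 nM, while compound 2 `Cc1cc(=O)n(-c2cccc(F)c2)nc1C(=O)Nc1ccc(Oc2ncnc3sccc23)c(F)c1` gives 24500 nM, the higher of the two numbers by a margin well beyond the usual scatter. Compound 1 and compound 2 differ at two places at once, so the contribution of either change cannot be separated from the other.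

Compound 3 `Cc1cc(=O)n(-c2ccc(F)cc2)nc1C(=O)Nc1ccc(Oc2ncnc3sccc23)c(F)c1` has not yet been measured. It is built from compound 2 by a single rearrangement: 4-fluorophenyl in place of 3-fluorophenyl on an aromatic nitrogen. Compound 3 thereby carries the same fluorophenyl group as compound 1 while keeping the rest of compound 2 unchanged.

Among the measured compounds shown here, with no single-change step available, the step from compound 2 to compound 3 is expected to fall somewhere between no change and the full gap separating compound 2 from compound 1. The expected step is a 6.1-fold lower number from compound 2 to compound 3 (0.79 log units; beyond the scatter), a move toward a lower number in this assay. Compound 3 is therefore estimated at 4000 nM, within a range from 800 nM to 20000 nM.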

Compound 3, half-maximal inhibitory concentration: 12500 nM
For compound 3 the middle estimate is 3.1-fold (0.49 log units) below the measured one; measured number inside the range.
By their numbers in this assay, from the lowest: compound 1; then compounds 3 and 2 (each within the scatter of the next).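

Moving the fluorine on the ring attached to the aromatic nitrogen gives a 2.0-fold lower number from compound 2 to compound 3 (0.29 log units; within the scatter) in this assay, so 3-fluorophenyl and 4-fluorophenyl cannot be told apart at this position, at least on the core shared by compound 2 and compound 3. The large gap between compound 1 and compound 2 therefore belongs almost entirely to the other place where they differ: with 4-fluorophenyl held constant, the two-ring group on the oxygen, built from the same atoms joined differently, gives a 27-fold higher number from compound 1 to compound 3 (1.42 log units; beyond the scatter). No measurement here shows what lies behind this sensitivity to how the two-ring group is joined.

Among the compounds shown here, the fluorine swap has been read on only one core, so it remains open whether 3-fluorophenyl would also match 4-fluorophenyl on the core of compound 1, where the numbers are lower. Also open, on these data alone, is how this position responds to a larger change than moving one fluorine, such as plain phenyl, 4-chlorophenyl or 4-methoxyphenyl on the aromatic nitrogen.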